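The source may report more compounds than this note shows. Statements on the series, on what has been measured and on what is new or still open speak of the compounds shown alone.

Measured compounds:
compound 1, `C=CCc1ccccc1OCCCNC(C)C`, gives 56 nM
compound 2, `C=CCc1cc(OC(=O)CC)ccc1OCCCNC(C)C`, gives 0.05 nM
compound 3, `C=CCc1cc(CO/N=C/C)ccc1OCCCNC(C)C`, gives 0.2 nM

All three share one core and differ only in the group carried on one aromatic carbon. In an assay for inhibition of squalene synthase (Rattus norvegicus), using microsomes (on this read-out lower numbers stand for stronger inhibition and higher numbers for weaker inhibition), compound 1, which carries a hydrogen there, gives the highest number. Putting propanoyloxy on that carbon gives a 1100-fold lower number from compound 1 to compound 2 (3.05 log units; beyond the scatter), and the five-atom group of compound 3 gives a 280-fold lower number from compound 1 to compound 3 (2.45 log units; beyond the scatter). Compound 3 therefore stands second highest of the three numbers; the nearest is compound 2, with a 4.0-fold higher number from compound 2 to compound 3 (0.60 log units; beyond the scatter).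

Compound 4 is `C=CCc1cc(N)ccc1OCCCNC(C)C`. The change is one nitrogen atom in place of a group of 5 heavy atoms (3 carbon, 1 nitrogen, 1 oxygen; no ring), on an aromatic carbon. The two large steps from compound 1 show that any of the five-atom groups tried on this carbon lowers the number strongly, while the modest step to compound 3 shows the identity of the group matters less. An amino group is neither hydrogen nor a five-atom group, so compound 4 is expected to fall somewhere between compound 1 and compound 3, meaning a step of a 25-fold higher number from compound 3 to compound 4 (1.40 log units; beyond the scatter) is expected. The estimate for compound 4 is 5 nM, with a range from 0.5 nM to 60 nM.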

Compound 4, half-maximal inhibitory concentration: 250 nM
Compound 4: the middle estimate sits 50-fold (1.70 log units) below what was measured, and the stated range ends below it.
By their numbers in this assay, from the lowest: compound 2; then compound 3; then compound 1; then compound 4.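

On this carbon, a group larger than hydrogen does not always lower the number in this assay: amino in place of hydrogen gives a 4.5-fold higher number from compound 1 to compound 4 (0.65 log units; beyond the scatter) and so moves toward weaker inhibition. Amino in place of the five-heavy-atom group gives a 1300-fold higher number from compound 3 to compound 4 (3.10 log units; beyond the scatter) and amino in place of propanoyloxy gives a 5000-fold higher number from compound 2 to compound 4 (3.70 log units; beyond the scatter) so the identity of the group here matters far more than the earlier compounds showed. Nothing available explains why amino behaves so differently from the other groups.

The compounds shown leave open whether adding to the amino nitrogen, as in an acetamide, would bring the number back down. They also leave open how a hydroxyl, a methoxy or an ester with a longer chain than propanoyloxy would compare on this carbon.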